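Swapping an Acetate Methyl for a Trifluoromethylphenyl Group

The source may report more compounds than this note shows. Statements on the series, on what has been measured and on what is new or still open speak of the compounds shown alone.

Measured compounds:
Compound 1, `CC(=O)O[C@H]1CC[C@]2(C)[C@H](CC[C@@](C)(O)[C@H]2CC[C@@H]2C(C)=CC[C@H]3[C@H](CC[C@]3(C)O)C2(C)C)OC1(C)C`: 47900 nM
Compound 2, `CC1=CC[C@H]2[C@@H]1CC=C(C)[C@@H](CC[C@H]1[C@]3(C)CC[C@H](OC(=O)c4ccccc4)C(C)(C)O[C@H]3CC[C@@]1(C)O)C2(C)C`: 23100 nM
Compound 3, `CC1=CC[C@H]2[C@H](CC[C@]2(C)O)C(C)(C)[C@@H]1CC[C@H]1[C@]2(C)CC/C(=N/O)C(C)(C)O[C@H]2CC[C@@]1(C)O`: 46800 nM

In a functional assay on MCF7 cells (Homo sapiens) for antiproliferative activity, read by MTT assay, with a stated time of 72 h (a lower number here means a stronger inhibitor, a higher number a weaker inhibitor), compound 1 gives 47900 nM, the highest of the three numbers. Compound 3 gives 46800 nM, which lies within the scatter of compound 1, so the two cannot be ranked. Compound 2 gives 23100 nM, a number beyond the scatter below that of compound 1.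

Compound 4, `CC1=CC[C@H]2[C@H](CC[C@]2(C)O)C(C)(C)[C@@H]1CC[C@H]1[C@]2(C)CC[C@H](OC(=O)c3ccc(C(F)(F)F)cc3)C(C)(C)O[C@H]2CC[C@@]1(C)O`, differs from compound 1 by 4-(trifluoromethyl)phenyl in place of methyl on a carbonyl carbon. Going by the values given here, no pair of measured compounds differs only in this way, so no direct step is available. The expected step of a 1.9-fold lower number from compound 1 to compound 4 (0.28 log units; within the scatter) is a modest lowering of the number, because compound 2 shows 23100 nM. Compound 4 is therefore estimated at 25000 nM, with a likely range from 10000 nM to 60000 nM.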

Compound 4, half-maximal inhibitory concentration: 23400 nM
Compound 4: middle estimate off by 1.1-fold (0.03 log units), on the high side; the measured number falls inside the stated range.
By their numbers in this assay, from the lowest: compounds 2, 4, 3 and 1 (each within the scatter of the next, the first and the last beyond it).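

In this assay, 4-(trifluoromethyl)phenyl in place of methyl on the carbonyl carbon gives a 2.0-fold lower number from compound 1 to compound 4 (0.31 log units; beyond the scatter) and so shows that this position tolerates a much larger group with an aromatic ring. Compound 2 gives 23100 nM and compound 4 gives 23400 nM in a pair within the scatter of each other, so the two cannot be ranked. Nothing shown explains the step.

Still open, going by these compounds, is how a saturated cyclohexyl ring or a longer alkyl chain would behave on this carbonyl carbon. An amine or a carboxylic acid on the aromatic ring is equally untested among the compounds shown.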